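A few compounds are considered here, and "the series" means these few. Any claim that something is new, unique, unknown or untested is made for them only; others in the source may bear on it.

Compounds measured so far:
- compound 1, `COC(=O)C1=C(C)NC(=O)NC1c1ccccc1`: in an assay for inhibition of beta-glucuronidase (Bos taurus), read by spectrophotometry, with a stated time of 30 min (on this read-out higher numbers stand for weaker inhibition and lower numbers for stronger inhibition), compound 1 gives "not active" (no number reported)
- compound 2, `COC(=O)C1=C(C)NC(=O)NC1c1ccc(Cl)cc1`: in this assay compound 2 gives 34200 nM

Compound 2 carries the only number shown in this assay; compound 1 stands beside it with no single number, only the report that it is not active. Nothing can be said about the size of the gap between them beyond that.

Compound 3, `COC(=O)C1=C(C)NC(=O)NC1c1ccc(C(C)C)cc1`, keeps the whole core of compound 2 and changes one group: isopropyl in place of chloro on an aromatic carbon. Among the measured compounds shown here, no measured pair tells how such a swap plays out here, so the expectation rests on the one number alone. Because compound 2 gives 34200 nM, the starting point is weak inhibition, and a step of modest size in either direction, or none beyond the scatter, is expected. Compound 3 is therefore estimated at 40000 nM in this assay, within 15000 nM to 120000 nM, an expected step of a 1.2-fold higher number from compound 2 to compound 3 (0.07 log units; within the scatter).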

Compound 3, half-maximal inhibitory concentration: "not active" (no number reported)
No number was reported for compound 3; the estimate stays without a comparison.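

In this assay, among the compounds shown here, compound 3 has no reported number, so no step from compound 2 to compound 3 can be read, and no measured evidence bears on this result. The compounds shown leave open how far compound 1 and compound 3 lie from compound 2.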